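This account rests on a few compounds, and the source may have more. Where it says the series, first, only, none or still open, it means among the compounds named here.

Compound 1 `CNc1cc(Oc2ccc(NC(=O)Nc3cccc(C(F)(F)F)c3)cc2C)ncn1`: in an assay on isolated protein for inhibition of serine/threonine-protein kinase TNNI3K (Homo sapiens) (a higher number here means a weaker inhibitor, a lower number a stronger inhibitor), compound 1 gives <= 10 nM, a limit of the assay.
Compound 2 `CNc1nccc(Oc2ccc(NC(=O)Nc3cccc(C(F)(F)F)c3)cc2)n1`: in this assay compound 2 gives 50 nM.
Compound 3 `CNc1cc(Oc2cc(C)c(NC(=O)Nc3cccc(C(F)(F)F)c3)cc2C)ncn1`: in this assay compound 3 gives 32 nM.

Compound 2 and compound 3 sit within the scatter of each other in this assay, and the value of compound 1 is a limit, so no ordering among the three is secure. Compound 4 `CC(C)Nc1cc(Oc2ccc(NC(=O)Nc3cccc(C(F)(F)F)c3)cc2)ncn1` is not yet measured. Compound 4 differs from compound 2 by 6-(isopropylamino)pyrimidin-4-yl in place of 2-(methylamino)pyrimidin-4-yl on an oxygen on an aromatic ring. Within the data shown here, no measured step covers this change; the only measured step, an at least 3.2-fold higher number from compound 1 to compound 3 (0.50 log units; beyond the scatter), concerns a methyl on an aromatic carbon and does not bear on it. The shared core of compound 1 carries the same arrangement of the amine on the pyrimidine as compound 4 does, and compound 1 gives <= 10 nM in this assay, a limit of the assay. Compound 4 is therefore expected at 15 nM, between 4 nM and 60 nM, a step of a 3.3-fold lower number from compound 2 to compound 4 (0.52 log units; beyond the scatter), with the note that the expectation rests on few compounds.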

Compound 4, half-maximal inhibitory concentration: 40 nM
Compound 4: middle estimate off by 2.7-fold (0.43 log units), on the low side, and the stated range covers the measured number.
By their numbers in this assay, from the lowest: compounds 3, 4 and 2 (each within the scatter of the next). At a limit, below all of these: compound 1.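

On the oxygen on an aromatic ring, 6-(isopropylamino)pyrimidin-4-yl in place of 2-(methylamino)pyrimidin-4-yl gives a 1.3-fold lower number from compound 2 to compound 4 (0.10 log units; within the scatter) in this assay. This position therefore accepts a change of both the amine's place on the pyrimidine and its alkyl group without a readable shift, something the earlier step, a methyl on an aromatic carbon, could not show.

From the compounds shown here alone, these two parts of the change remain unseparated, and the effect of a longer chain, a cyclopropyl group or an unsubstituted amino group on the pyrimidine remains open. Compound 1 stands at a limit, so its distance from the other compounds cannot be read: the limit of <= 10 nM in this assay, at which 1 of the 4 values shown sits.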